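The source may hold more compounds than are shown below. What is called first, only, known or untested is meant among the compounds shown, and "the series" means these compounds.

Measured so far:
compound 1 `O=C(CNC(=O)c1cc(Cl)ccc1O)Nc1cccc(Cl)c1` — > 10000 nM
compound 2 `CC(C)[C@H](NC(=O)c1cc(Cl)ccc1O)C(=O)Nc1cccc(Cl)c1` — > 10000 nM

In a functional assay on MCF7 cells (Homo sapiens) for cytotoxicity, with a stated time of 72 h (on this read-out lower numbers stand for stronger inhibition and higher numbers for weaker inhibition), compound 1 gives > 10000 nM, which is a limit of the assay and not a number. Compound 2 in this assay gives > 10000 nM, again only a limit. The step that the two limits leave unreadable from compound 1 to compound 2 cannot be read because both values sit at the limit of > 10000 nM in this assay, at which 2 of the 2 values shown sit; the isopropyl group entering on the saturated chain carbon bound to the amide-type nitrogen and the carbonyl carbon left no readable trace.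

Compound 3 `CC(C)[C@@H](NC(=O)c1cc(Cl)ccc1O)C(=O)Nc1cccc(Cl)c1` differs from compound 2 only in configuration: the two compounds have the same atoms and bonds and differ only in configuration as drawn: 1 of 1 stereo elements differ; a stereocentre at a saturated chain carbon is drawn S in compound 2 and R in compound 3. For the measured compounds named here, no measured step bears on a change of configuration at that stereocentre, and the only measured step, a step that the two limits leave unreadable from compound 1 to compound 2, is itself unreadable. Since compound 2 reaches only a limit in this assay, the working expectation for compound 3 is the same outcome, most probably again a limit rather than a number. Compound 3 is therefore estimated at 20000 nM in this assay, with a range from 8000 nM to 60000 nM. The step that the limit leaves unreadable from compound 2 to compound 3 is expected to be none beyond the scatter.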

Compound 3, half-maximal inhibitory concentration: > 10000 nM
Compound 3: no number, only a limit (the forecaster's own chance of this, stated with the estimate: 85%); the middle value is on the limit's open side.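

No new step can be read in this assay for compound 1, compound 2 or compound 3, because all three stand at a limit of the assay and not at a number: the limit of > 10000 nM in this assay, at which 3 of the 3 values shown sit. The compounds shown leave open whether the isopropyl group or the configuration at the stereocentre has any bearing on cytotoxicity.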